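The source may report more compounds than this note shows. Statements on the series, on what has been measured and on what is new or still open speak of the compounds shown alone.

Compounds measured so far in a functional assay on BGC-823 cells (Homo sapiens) for cytotoxicity, read by CCK-8 assay, with a stated time of 72 h; on this read-out lower numbers stand for stronger inhibition and higher numbers for weaker inhibition:

compound 1 `C=CCn1c(=O)/c(=C\c2cc(F)ccc2C)[nH]c(=O)/c1=C\c1ccccc1OC`, with compound 1 giving 1600 nM
compound 2 `COc1ccccc1/C=c1\c(=O)[nH]/c(=C/c2ccccc2Cl)c(=O)n1C`, with compound 2 giving 300 nM
compound 3 `C=CCn1c(=O)/c(=C\c2cccc(Cl)c2)[nH]c(=O)/c1=C\c1ccccc1OC`, with compound 3 giving 4600 nM

Compound 3 gives the highest number of the three; compound 1 sits nearest to it, and compound 2 furthest. Going by the values given here, the one step that touches compound 3 directly is a 2.9-fold higher number from compound 1 to compound 3 (0.46 log units; beyond the scatter), which separates compound 1 from compound 3 on the basis of the aryl group on the double-bonded chain carbon.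

Compound 4 `C=CCn1c(=O)/c(=C\c2ccccc2Cl)[nH]c(=O)/c1=C\c1ccccc1OC` is still to be measured. It differs from compound 3 in this way: 2-chlorophenyl in place of 3-chlorophenyl on a double-bonded chain carbon bound to an aromatic carbon.

Among the compounds with values here, no measured step covers exactly this exchange of one chlorophenyl for the other. Compound 2 carries the same 2-chlorophenyl that enters in compound 4, but with a different group on the ring nitrogen, so compound 2 and compound 4 cannot be compared by a single step; compound 2 does, however, give the lowest number of the three. Taken together with the step from compound 1 to compound 3, which shows that the aryl group alone can move the number beyond the scatter, a downward step is expected, as a 4.6-fold lower number from compound 3 to compound 4 (0.66 log units; beyond the scatter). Compound 4 is therefore estimated at 1000 nM, within 300 nM to 3500 nM.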

Compound 4, half-maximal inhibitory concentration: 4600 nM
Compound 4: the middle estimate sits 4.6-fold (0.66 log units) below what was measured, and the stated range ends below it.
By their numbers in this assay, from the lowest: compound 2; then compound 1; then compounds 3 and 4 (each within the scatter of the next).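

In this assay, 2-chlorophenyl in place of 3-chlorophenyl on a double-bonded chain carbon bound to an aromatic carbon makes no difference, with no change at the digits printed from compound 3 to compound 4 (within the scatter), so with this group on the aromatic nitrogen the two chlorophenyl groups cannot be told apart. The 2-chlorophenyl group alone therefore does not bring the low number of compound 2, and the one change of vinyl in place of hydrogen on a saturated chain carbon bound to an aromatic nitrogen gives a 15-fold higher number from compound 2 to compound 4 (1.19 log units; beyond the scatter), the largest step among these compounds and the first to show how much that place matters. The 5-fluoro-2-methylphenyl group also keeps its edge over the 2-chlorophenyl group, with a 2.9-fold higher number from compound 1 to compound 4 (0.46 log units; beyond the scatter), as it did over the 3-chlorophenyl group. No measurement at hand explains any of these steps.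

The compounds shown leave open whether 3-chlorophenyl would match 2-chlorophenyl with the smaller nitrogen group of compound 2 as well. They also leave open how 4-chlorophenyl at the aryl place, or a longer chain or a chain ending in an amine on the aromatic nitrogen, would read in this assay.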